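This account rests on a few compounds, and the source may have more. Where it says the series, first, only, none or still open, it means among the compounds named here.

The series is examined in a functional assay on Shh Light II cells (Mus musculus) for inhibition, read by a luciferase reporter; on this read-out higher numbers stand for weaker inhibition and lower numbers for stronger inhibition. Compound 2, `O=C(Nc1ncccc1Cl)N1CCC(c2nc(-c3ccc4ccccc4n3)no2)CC1`, gives 2800 nM there, which is the highest of the three numbers recorded. Compound 1, `C[C@@H]1C[C@H](c2nc(-c3ccc4ccccc4n3)no2)CCN1C(=O)Nc1ccccc1Cl`, gives 2400 nM, a number that sits within the scatter of the reading for compound 2, so the two cannot be told apart. Compound 3, `Cn1c(-c2noc(C3CCN(C(=O)NC4CCCCC4)CC3)n2)nc2ccccc21`, gives 89 nM, and the gap from compound 2 to compound 3 lies well beyond the scatter; compound 3 also carries a different core, so the comparison does not isolate any single change.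

The step to compound 4, `O=C(OCc1ccccc1)N1CCC(c2nc(-c3ccc4ccccc4n3)no2)CC1`, alters only the group on the carbonyl carbon: benzyloxy in place of (3-chloropyridin-2-yl)amino on a carbonyl carbon. For the measured compounds named here, no pair of measured compounds shows this difference, so nothing measured speaks directly to it. Compound 4 is expected to land close to compound 2, with the step of a 1.4-fold higher number from compound 2 to compound 4 (0.15 log units; within the scatter) estimated as slight and, if anything, toward a higher number. The estimate for compound 4 in this assay is 4000 nM, within 1200 nM to 13000 nM.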

Compound 4, half-maximal inhibitory concentration: > 2500 nM
Compound 4 ended at the assay's limit (the forecaster's own chance of this, stated with the estimate: 15%); the middle value is on the limit's open side.
By their numbers in this assay, from the lowest: compound 3; then compounds 1 and 2 (each within the scatter of the next).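

In this assay compound 4 gives > 2500 nM, which is a limit of the assay and not a number, so no step from compound 2 to compound 4 can be read: the limit of > 2500 nM in this assay, at which 1 of the 4 values shown sits.

The compounds shown leave open whether benzyloxy in place of (3-chloropyridin-2-yl)amino on a carbonyl carbon changes the reading at all.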